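The source may hold more compounds than are shown below. What is called first, only, known or untested is meant among the compounds shown, and "the series" means these compounds.

Within the data shown here, compound 3 `Cc1ccccc1-n1nc(C)c2c1NC(=O)[C@H](C)S[C@@H]2c1ccc(-c2cc3ccccc3o2)cc1` gives 17% in an assay on isolated protein for agonist activity at Bile acid receptor (Homo sapiens), read by AlphaScreen, with a stated time of 30 min (a lower number here means a smaller maximal response, a higher number a larger maximal response), the lowest of the three numbers so far. Compound 1 `COc1ccc(Oc2ccc([C@H]3S[C@@H](C)C(=O)Nc4c3c(C)nn4-c3ccccc3C)cc2)cc1` gives 70% in this assay, and compound 2 `COc1ccccc1Oc1ccc([C@H]2S[C@@H](C)C(=O)Nc3c2c(C)nn3-c2ccccc2C)cc1` gives 240%. Both steps into compound 3 were large and downward, a number 53 percentage points lower from compound 1 to compound 3 (beyond the scatter) and a number 223 percentage points lower from compound 2 to compound 3 (beyond the scatter), while a number 170 percentage points higher from compound 1 to compound 2 (beyond the scatter) shows how far the response can move on a change at this end of the molecule. Compound 4 `Cc1ccccc1-n1nc(C)c2c1NC(=O)[C@H](C)S[C@@H]2c1ccc(-c2ccco2)cc1` differs from compound 3 by furan-2-yl in place of 1-benzofuran-2-yl on an aromatic carbon. Among the measured compounds shown here, no measured step removes a six-membered aromatic ring of carbon only from this group, so the direction is open. A moderate upward step is expected, a number 13 percentage points higher from compound 3 to compound 4 (beyond the scatter). Compound 4 is estimated to give 30%, within 5% to 90%.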

Compound 4, largest response reached (reported as efficacy), in percent of the reference or control that the assay uses: 32%
Beside the measured number, compound 4's estimate is 2 percentage points below it, and the stated range covers the measured number.
By their numbers in this assay, from the lowest: compound 3; then compound 4; then compound 1; then compound 2.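

Removing the six-membered aromatic ring of carbon only from the 1-benzofuran-2-yl group gives a number 15 percentage points higher from compound 3 to compound 4 (beyond the scatter) in this assay, so the size of the ring system at this place changes the response only modestly. The furan-2-yl group still falls well short of both methoxyphenoxy groups, with a number 208 percentage points lower from compound 2 to compound 4 (beyond the scatter) and a number 38 percentage points lower from compound 1 to compound 4 (beyond the scatter). Nothing available explains these differences.

Still open, as far as these compounds go, is how a morpholine amine or a carboxylic acid on this aromatic carbon would compare with the furan-2-yl and 2-methoxyphenoxy groups.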